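The source may report more compounds than this note shows. Statements on the series, on what has been measured and on what is new or still open speak of the compounds shown alone.

Compound 1 `Cc1ccc(NC(=O)c2cccc(/C=C3\CC(=O)N(c4ccccc4)C3=O)c2)cc1` was examined in an ADME assay on SW480 cells (Homo sapiens) for cytotoxicity, read by MTT assay, with a stated time of 72 h; a higher number here means a weaker inhibitor, a lower number a stronger inhibitor. In this assay compound 1 gives only a limit, > 100000 nM. Compound 2 `CCc1ccc(NC(=O)c2cccc(/C=C3\CC(=O)N(c4ccccc4)C3=O)c2)cc1` also reaches only a limit in this assay, > 100000 nM. Compound 3 `CCc1cccc(NC(=O)c2cccc(/C=C3\CC(=O)N(Cc4ccccc4)C3=O)c2)c1` gives 91500 nM in this assay. The step that the two limits leave unreadable from compound 1 to compound 2 is not readable; both of its ends are limits. Two of the three values sit at the limit of > 100000 nM in this assay, at which 2 of the 3 values shown sit, and compound 1 stands among them without a number of its own. Compound 4 `Cc1ccc(NC(=O)c2cccc(/C=C3\CC(=O)N(c4ccccc4)C3=O)c2)cc1C` has not yet been measured; it differs from compound 1 by methyl in place of hydrogen on an aromatic carbon, turning the 4-methylphenyl group into a 3,4-dimethylphenyl group. No measured step bears directly on this change: the one step shown is itself unreadable, and compound 3 differs from the others in more than one place. Nothing shown therefore points to a step beyond the scatter in this assay in either direction. Compound 4 is accordingly expected to give about 100000 nM in this assay, within 50000 nM to 300000 nM, and this estimate means a step of a number no higher from compound 1 to compound 4 (the limit leaves the size open).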

Compound 4, half-maximal inhibitory concentration: > 100000 nM
Compound 4: only a limit was reported; the forecaster's own chance of this, stated with the estimate: 70%; the middle value lies on the limit itself.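

In this assay compound 4 gives only a limit, > 100000 nM. Its steps from compound 1 and from compound 2 cannot be read, as both ends of each are limits. The compounds shown leave open whether the added methyl changes the read-out at all, since most values stand at one limit: the limit of > 100000 nM in this assay, at which 3 of the 4 values shown sit.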